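A few compounds are considered here, and "the series" means these few. Any claim that something is new, unique, unknown or untested is made for them only; others in the source may bear on it.

Series notes. Compound 1 `CCCCCN1C(=O)C/C(=C\c2cccc(C(=O)Nc3ccc(C)cc3)c2)C1=O` and compound 3 `CCCCCN1C(=O)C/C(=C\c2cccc(C(=O)NCCCC)c2)C1=O` share their core with compound 2 `Cc1cccc(NC(=O)c2cccc(/C=C3\CC(=O)N(c4ccccc4)C3=O)c2)c1`. In an ADME assay on NCM460 cells (Homo sapiens) for cytotoxicity, read by MTT assay, with a stated time of 72 h (on this read-out lower numbers stand for stronger inhibition and higher numbers for weaker inhibition), compound 1 reports only the limit > 100000 nM. Compound 3 likewise reports only the limit > 100000 nM in this assay. Compound 2 too stands at a limit in this assay, > 100000 nM. Within the data shown here, what the series shows is the limit of > 100000 nM in this assay, at which 3 of the 3 values shown sit; the only step between compounds differing in one place, a step that the two limits leave unreadable from compound 1 to compound 3, therefore carries no readable size. Compound 4 `CCOc1ccc(NC(=O)c2cccc(/C=C3\CC(=O)N(c4ccccc4)C3=O)c2)cc1`, not yet measured, differs from compound 2 by 4-ethoxyphenyl in place of 3-methylphenyl on an amide-type nitrogen. Among the measured compounds shown here, no measured step bears on this change; with every value at the limit, no step beyond the scatter is expected in this assay, and a limit again is the likeliest outcome. Compound 4 is therefore expected at 150000 nM, within 60000 nM to 400000 nM, an expected step that the limit leaves unreadable from compound 2 to compound 4.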

Compound 4, half-maximal inhibitory concentration: > 100000 nM
Compound 4 ended at the assay's limit; the forecaster's own chance of this, stated with the estimate: 85%; the middle value is on the limit's open side.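

Compound 2 and compound 4 both stand at a limit in this assay, so no step can be read between them: the limit of > 100000 nM in this assay, at which 4 of the 4 values shown sit.

The compounds shown leave open the size of any step in this assay, including that for 4-ethoxyphenyl in place of 3-methylphenyl.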